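The compounds below may be only part of what the source reports. "The series", "measured", "known", "first", "only" and "open" are said of these compounds alone.

Compound 2 `CN(C)c1ccc2cc(NC(=O)CCc3ccc(C(F)(F)F)cc3)ccc2n1` carries a dimethylamino group on the core, and in a functional assay on HEK293 cells for activation of melanin-concentrating hormone receptor 1 (Rattus norvegicus), read by inositol phosphate accumulation (on this read-out higher numbers stand for an effect only at larger amounts of compound and lower numbers for an effect already at smaller amounts), compound 2 gives 110 nM, the lowest of the two numbers at hand. For the measured compounds named here, compound 1 `O=C(CCc1ccc(C(F)(F)F)cc1)Nc1ccc2nc(N3CC4CC3CN4)ccc2c1` is its only neighbour, and in this assay compound 1 gives 490 nM. Going by the values given here, the one measured step between them, a 4.5-fold lower number from compound 1 to compound 2 (0.65 log units; beyond the scatter), shows that the dimethylamino group sits where a group of two five-membered non-aromatic rings does not. Compound 3 `O=C(CCc1ccc(C(F)(F)F)cc1)Nc1ccc2nc(N3CCC4(CCNC4)C3)ccc2c1` goes the other way: a group of 9 heavy atoms (7 carbon, 2 nitrogen; 2 five-membered non-aromatic rings with 1 hetero atom each) in place of a group of 3 heavy atoms (2 carbon, 1 nitrogen; no ring), on an aromatic carbon, a group of the same kind as that in compound 1, with one hydrogen-bond donor and two acceptors. Among the compounds with values here, the step from compound 1 to compound 2 is the only guide, and it points to a higher number for compound 3. Compound 3 is therefore expected to give about 400 nM in this assay, within 150 nM to 1200 nM, which means an expected step of a 3.6-fold higher number from compound 2 to compound 3 (0.56 log units; beyond the scatter).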

Compound 3, half-maximal effective concentration: 140 nM
The estimate for compound 3 lay 2.9-fold (0.46 log units) above the measured number; the measured number lies below the stated range.
By their numbers in this assay, from the lowest: compounds 2 and 3 (each within the scatter of the next); then compound 1.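

In this assay, a 1.3-fold higher number from compound 2 to compound 3 (0.10 log units; within the scatter) shows that this aromatic carbon next to the ring nitrogen can carry a group of 9 heavy atoms with two five-membered non-aromatic rings in place of dimethylamino without a change beyond the scatter. a 3.5-fold lower number from compound 1 to compound 3 (0.54 log units; beyond the scatter) shows that two groups with the same count of such rings can still give clearly different numbers here, and across the three compounds the number does not follow heavy-atom count, since the group of 7 heavy atoms in compound 1 stands apart from both the smaller and the larger group. No measurement at hand explains this difference. Going by these compounds, it remains open how a piperazine or morpholine ring would read at this position. Also open, on these data alone, is whether a methyl group on the ring nitrogen carrying the hydrogen in the group of compound 3 would shift the number.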